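The source may report more compounds than this note shows. Statements on the series, on what has been measured and on what is new or still open speak of the compounds shown alone.

Compound 1 `Cc1nc(Nc2cccc(Cl)c2)sc1C(=O)/C=C/c1ccccc1`: in a functional assay on PC-3 cells (Homo sapiens) for cytotoxicity, read by MTT assay (a lower number here means a stronger inhibitor, a higher number a weaker inhibitor), compound 1 gives > 25000 nM, which is a limit of the assay rather than a number.
Compound 2 `Cc1ccccc1Nc1nc(C)c(C(=O)/C=C/c2ccccc2)s1`: in this assay compound 2 gives > 25000 nM, again only a limit.
Compound 3 `COc1cccc(/C=C/C(=O)c2sc(Nc3ccccc3C)nc2C)c1`: in this assay compound 3 gives > 25000 nM, also a limit.

All three measured compounds share one core and differ only in the groups hung on it. From compound 2 to compound 1 the change is 3-chlorophenyl in place of 2-methylphenyl on a nitrogen on an aromatic ring, and the two values give a step that the two limits leave unreadable from compound 2 to compound 1. From compound 2 to compound 3 the change is methoxy in place of hydrogen on an aromatic carbon, and here too the values give a step that the two limits leave unreadable from compound 2 to compound 3. Since (the limit of > 25000 nM in this assay, at which 3 of the 3 values shown sit), neither step can be sized: a change that starts at a limit and ends at the same limit tells nothing about its direction.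

Compound 4 `COc1cccc(/C=C/C(=O)c2sc(Nc3cccc(Cl)c3)nc2C)c1` is not yet measured. It differs from compound 3 by 3-chlorophenyl in place of 2-methylphenyl on a nitrogen on an aromatic ring, which is the same change already made from compound 2 to compound 1, at a place described in the same words. Among the measured compounds shown here, because of the limit of > 25000 nM in this assay, at which 3 of the 3 values shown sit, the one precedent for this change did not lift a compound out of the limit. The step from compound 3 to compound 4 is therefore expected to read a step that the limit leaves unreadable from compound 3 to compound 4, meaning no readable movement. For compound 4 the estimate in this assay is 50000 nM, most likely reported again as a limit, with a range from 12000 nM to 200000 nM.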

Compound 4, half-maximal inhibitory concentration: > 25000 nM
Compound 4 ended at the assay's limit; the forecaster's own chance of this, stated with the estimate: 85%; the middle value lies beyond the limit too.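

In this assay compound 4 gives > 25000 nM, which is again a limit. Its steps from compound 3 and from compound 1 therefore cannot be read, in size or in direction: the limit of > 25000 nM in this assay, at which 4 of the 4 values shown sit.

The compounds shown leave open whether any change on the shared core gives a readable number, and what 3-chlorophenyl or methoxy would do on a compound that starts from one.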